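Tert-butyl for benzyl on the shared core

This account rests on a few compounds, and the source may have more. Where it says the series, first, only, none or still open, it means among the compounds named here.

Compound 2 `COC(=O)[C@@H]1C[C@@]2(CC=C(C)C)c3ccccc3N3C(=N)[C@H](Cc4ccccc4)N1[C@H]32` stands in a functional assay on MDA-MB-231 cells (Homo sapiens) for cytotoxicity, read by sulforhodamine B assay, with a stated time of 48 h (on this read-out lower numbers stand for stronger inhibition of growth and higher numbers for weaker inhibition of growth), at the limit of the assay, reported as > 100000 nM rather than as a number, and so it sits at the limit of > 100000 nM in this assay, at which 1 of the 2 values shown sits. Compound 1 `COC(=O)[C@@H]1C[C@@]2(CC=C(C)C)c3ccccc3N3C(=N)C(C)(C)N1[C@H]32`, which carries two methyl groups on the same saturated ring carbon, gives 11000 nM in this assay. Compound 3 `COC(=O)[C@@H]1C[C@@]2(CC=C(C)C)c3ccccc3N3C(=N)[C@H](C(C)(C)C)N1[C@H]32` is the not yet measured partner of compound 2; it differs by tert-butyl in place of benzyl on a saturated ring carbon, a change described as tert-butyl in place of benzyl on a saturated ring carbon. Among the measured compounds shown here, no step between measured compounds covers this change, so the direction is uncertain; a branched alkyl group here is expected to fall somewhere between the outcome of compound 1 and the limit of compound 2, which makes a move toward stronger inhibition than compound 2 plausible but far from assured. Compound 3 is expected to give 60000 nM in this assay, with a range from 12000 nM to 300000 nM. That estimate corresponds to a step of an at least 1.6-fold lower number from compound 2 to compound 3 (0.22 log units; that floor lies within the scatter).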

Compound 3, concentration for 50% growth inhibition: 15200 nM
Compound 3: the middle estimate sits 3.9-fold (0.60 log units) above what was measured; the range from low to high includes it.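

The group on this saturated ring carbon clearly matters on the shared core: in this assay, replacing benzyl with tert-butyl gives an at least 6.5-fold lower number from compound 2 to compound 3 (0.81 log units; beyond the scatter) and shows that growth inhibition can be recovered at this position. Compound 2 stands at a limit of the assay and not at a number, so the step is only a floor: the limit of > 100000 nM in this assay, at which 1 of the 3 values shown sits. With tert-butyl, compound 3 gives a measured 15200 nM and, like compound 1, which carries two methyl groups on the same saturated ring carbon and gives 11000 nM, has a numerical reading.

As far as these compounds go, the true size of the step stays open, as does whether the aromatic ring of benzyl or its overall size accounts for the difference. From the compounds shown here alone, how an amine, a carboxylic acid or a longer chain such as n-butyl on this carbon would read also remains unknown.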